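Adding One Carbon to the Carbamate of Compound 3

A few compounds are considered here, and "the series" means these few. Any claim that something is new, unique, unknown or untested is made for them only; others in the source may bear on it.

The compounds here share one core and differ only in the group attached through an ester or carbamate. Compound 3 `COc1cc(C(=O)N2CCN(C(=O)c3cc(OC)c(OC)c(OC)c3)C(COC(=O)NC(C)(C)C)C2)cc(OC)c1OC` carries a (tert-butyl)amino group on that carbonyl carbon, and in a functional assay (Oryctolagus cuniculus) for inhibition of platelet-activating factor receptor (Cavia porcellus) (on this read-out higher numbers stand for weaker inhibition and lower numbers for stronger inhibition), compound 3 gives 130 nM. Among the entries with a single number it stands lowest; the nearest is compound 2 `COc1cc(C(=O)N2CCN(C(=O)c3cc(OC)c(OC)c(OC)c3)C(COC(=O)C3CCCCC3)C2)cc(OC)c1OC`, which has cyclohexyl in the same place and gives 290 nM. The swap of cyclohexyl for (tert-butyl)amino gives a 2.2-fold lower number from compound 2 to compound 3 (0.35 log units; beyond the scatter). Compound 1 `COc1cc(C(=O)N2CCN(C(=O)c3cc(OC)c(OC)c(OC)c3)C(COC(=O)C(C)(C)C)C2)cc(OC)c1OC`, with tert-butyl directly on the carbonyl carbon, was measured repeatedly, giving (the several entries of compound 1 in this assay, 100 nM; 100 nM; 120 nM (3 entries)), so compound 1 gives 100 nM; 100 nM; 120 nM (3 entries).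

Compound 4 `CCC(C)(C)NC(=O)OCC1CN(C(=O)c2cc(OC)c(OC)c(OC)c2)CCN1C(=O)c1cc(OC)c(OC)c(OC)c1` differs from compound 3 by methyl in place of hydrogen on a saturated chain carbon, two bonds along the chain from an amide-type nitrogen. Among the measured compounds shown here, no measured step touches this part of the molecule; the one measured step, the modest change from compound 2 to compound 3, replaces the whole group, and the spread among compounds 1, 2 and 3 is narrow. Compound 4 is therefore expected to sit close to compound 3, with a step of a 1.1-fold higher number from compound 3 to compound 4 (0.03 log units; within the scatter) that is not expected to go beyond the scatter. The estimate for compound 4 is 140 nM, between 60 nM and 330 nM.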

Compound 4, half-maximal inhibitory concentration: 320 nM
Compound 4: the middle estimate sits 2.3-fold (0.36 log units) below what was measured; the measured number falls inside the stated range.
By their numbers in this assay, from the lowest: compound 3; then compounds 2 and 4 (each within the scatter of the next).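

The (tert-butyl)amino group turns out to be sensitive to a single added carbon: in this assay, methyl in place of hydrogen on this saturated chain carbon gives a 2.5-fold higher number from compound 3 to compound 4 (0.39 log units; beyond the scatter), which means weaker inhibition. That small change removes the edge that compound 3 held over the cyclohexyl ester, as there is a 1.1-fold higher number from compound 2 to compound 4 (0.04 log units; within the scatter). So the narrow spread among the earlier compounds did not mean that this end of the molecule tolerates any added bulk, and nothing in the data shown explains why this one carbon matters.

Going by these compounds, it remains open whether a longer chain at this carbon, such as 1,1-dimethylbutyl, would weaken inhibition further. On these data alone, it is also open whether a smaller group on the carbamate nitrogen, such as isopropyl, would match or improve on compound 3.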